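The source may hold more compounds than are shown below. What is called first, only, known or untested is meant among the compounds shown, and "the series" means these compounds.

Of the compounds shown here, three sharing one core have been tested in a functional assay on SW480 cells (Homo sapiens) for antiproliferative activity; on this read-out lower numbers stand for stronger inhibition and higher numbers for weaker inhibition. In it, compound 1 `COc1ccccc1/C=C/C(=O)c1ccc(OCCn2cc(CN3C(=O)/C=C/C(C)(C)C/C=C(\C)CC/C=C/3C)nn2)cc1O` gives 0.9 ug/mL, compound 2 `C/C1=C\CC(C)(C)/C=C/C(=O)N(Cc2cn(CCOc3ccc(C(=O)/C=C/c4ccc(C(C)C)cc4)c(O)c3)nn2)/C(C)=C/CC1` gives 0.85 ug/mL, and compound 3 `COc1cccc(/C=C/C(=O)c2ccc(OCCCN3C(=O)/C=C/C(C)(C)C/C=C(\C)CC/C=C/3C)cc2)c1` gives 1.34 ug/mL. The value of compound 3 lies within the usual scatter of both others, so these three cannot be ranked.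

Compound 4 `C/C1=C\CC(C)(C)/C=C/C(=O)N(CCCOc2ccc(C(=O)/C=C/c3ccc(C)cc3)cc2)/C(C)=C/CC1` has not yet been measured. It carries 4-methylphenyl in place of 3-methoxyphenyl on a double-bonded chain carbon bound to a double-bonded chain carbon, and the count of that change reads (4-methylphenyl in place of 3-methoxyphenyl on a double-bonded chain carbon bound to a double-bonded chain carbon).

Among the compounds with values here, only one measured step bears on this, a swap at the same place: 4-isopropylphenyl in place of 2-methoxyphenyl gives a 1.1-fold lower number from compound 1 to compound 2 (0.02 log units; within the scatter). That step stays within the scatter, although compound 1 and compound 2 have a different chain on the core, so it is only a loose guide. No shift beyond the scatter is therefore expected in this assay, and no direction can be favoured.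

The expected step is a 1.1-fold lower number from compound 3 to compound 4 (0.05 log units; within the scatter). For compound 4 the estimated value is 1.2 ug/mL, with an expected range of 0.6 ug/mL to 2.4 ug/mL.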

Compound 4, half-maximal inhibitory concentration: 1.57 ug/mL
Compound 4: the middle estimate sits 1.3-fold (0.12 log units) below what was measured; low and high end bracket the measured number.
By their numbers in this assay, from the lowest: compounds 2, 1, 3 and 4 (each within the scatter of the next).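

With this assay, the swap of 3-methoxyphenyl for 4-methylphenyl gives a 1.2-fold higher number from compound 3 to compound 4 (0.07 log units; within the scatter), so a second change on a double-bonded chain carbon bound to a double-bonded chain carbon stays within the scatter, this time on the chain shared by compound 3 and compound 4. This swap also removes the hydrogen-bond acceptor carried by the 3-methoxyphenyl group, and the read-out still does not separate the two compounds. No measurement shown here offers an explanation for this result.

From the compounds shown here alone, whether any group at this position can move the number beyond the scatter remains open, as all four compounds carry a substituted phenyl there. Going by these compounds, what an amine or a carboxylic acid on that phenyl ring would do is unknown, and so is whether 4-methylphenyl would read the same on the chain of compound 1.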